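The compounds below may be only part of what the source reports. "The series", "measured", "known", "first", "only" and "open" are said of these compounds alone.

Compounds 1, 2, 3 and 4 share one core and differ only in the group carried on the saturated chain carbon bound to the amide-type nitrogen in the ring. Compound 1 `CC(=O)Nc1ccc(CN2CCC=C(CCC(=O)NO)C2=O)cc1` carries an acetamido-substituted ring. In a functional assay on PC-3 cells (Homo sapiens) for inhibition, read by sulforhodamine B assay (on this read-out lower numbers stand for stronger inhibition of growth and higher numbers for weaker inhibition of growth), compound 1 gives > 10000 nM, which is a limit of the assay rather than a number. Compound 3 `O=C(CCC1=CCCN(Cc2ccc([N+](=O)[O-])cc2)C1=O)NO` carries a nitro group instead and in this assay gives 3010 nM. Among the compounds with values here, the only measured step is an at least 3.3-fold lower number from compound 1 to compound 3 (0.52 log units; beyond the scatter), and its starting point is the limit (the limit of > 10000 nM in this assay, at which 1 of the 3 values shown sits), so its true size is not known beyond the stated minimum.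

Compound 2 `O=C(CCC1=CCCN(Cc2ccc(F)cc2)C1=O)NO` has no result in this assay: for compound 2 the entry reads "not determined" (no result reported), neither a number nor a limit, so it stands nowhere on the scale shown.

Compound 4 `Cc1ccccc1CN1CCC=C(CCC(=O)NO)C1=O` differs from compound 2 as follows: 2-methylphenyl in place of 4-fluorophenyl on a saturated chain carbon bound to an amide-type nitrogen in a ring. Within the data shown here, neither the step from compound 1 to compound 3 nor any other measured pair involves a methyl or a fluorine, so no measured step bears directly on this change, and no direction can be drawn from the data. The expected value for compound 4 in this assay is estimated at 4000 nM, within a range from 1200 nM to 15000 nM.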

Compound 4, concentration for 50% growth inhibition: > 10000 nM
Compound 4 gave a limit, no number; the forecaster's own chance of this, stated with the estimate: 30%; middle value at least 2.5-fold (0.39 log units) from the limit.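

In this assay compound 4 gives > 10000 nM, a limit and not a number. With no result shown for compound 2, no step between compound 2 and compound 4 can be read. Left open is how 2-methylphenyl and 4-fluorophenyl compare here, and where compound 4 truly stands.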